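Lengthening the ester chain on a chromone core

The source may hold more compounds than are shown below. What is called first, only, known or untested is meant among the compounds shown, and "the series" means these compounds.

Compound 2 `CCC(=O)OCc1c(F)c(N)c2c(=O)cc(-c3ccc(N)c(F)c3)oc2c1F` is one of two compounds with results in a functional assay on HeLa cells (Homo sapiens) for cytotoxicity, read by neutral red uptake, with a stated time of 3 days; on this read-out higher numbers stand for weaker inhibition and lower numbers for stronger inhibition. Compound 1 `Nc1ccc(-c2cc(=O)c3c(N)c(F)c(Br)c(F)c3o2)cc1F` gives > 100000 nM in this assay, and this is a limit of the assay rather than a number. Compound 2 gives 69000 nM, the only actual number shown. The step of an at least 1.4-fold lower number from compound 1 to compound 2 (0.16 log units; that floor lies within the scatter) is only a floor because of the limit of > 100000 nM in this assay, at which 1 of the 2 values shown sits.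

Compound 3 `CCCCCCCCCC(=O)OCc1c(F)c(N)c2c(=O)cc(-c3ccc(N)c(F)c3)oc2c1F` differs from compound 2 by heptyl in place of hydrogen on a saturated chain carbon, two bonds along the chain from a carbonyl carbon. Going by the values given here, the single measured step swaps bromo for (propanoyloxy)methyl, a change at a different position and of a different kind, so it tells little about what a longer chain on the ester does. Among the compounds with values here, with no measured step that concerns chain length, the expectation is that compound 3 stays close to compound 2 in this assay, with a step of a 1.4-fold lower number from compound 2 to compound 3 (0.14 log units; within the scatter) expected to lie within the scatter. Compound 3 is therefore estimated at 50000 nM, with a range from 15000 nM to 150000 nM, and a real chance that this assay again reports only a limit.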

Compound 3, half-maximal inhibitory concentration: > 100000 nM
Compound 3 was reported as a limit; the forecaster's own chance of this, stated with the estimate: 30%; at least 2.0-fold (0.30 log units) between middle value and limit.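

In this assay compound 3 gives > 100000 nM, which is a limit of the assay and not a number. Heptyl in place of hydrogen on a saturated chain carbon, two bonds along the chain from a carbonyl carbon, is the first measured change to the ester chain itself, and the result is an at least 1.4-fold higher number from compound 2 to compound 3 (0.16 log units; that floor lies within the scatter), so lengthening propanoyl to nonylcarbonyl produced no lower number that this assay could show. How far the longer chain really moves the number stays unknown, because this step is only a floor that does not clear the usual scatter: the limit of > 100000 nM in this assay, at which 2 of the 3 values shown sit.

The compounds shown leave open what a shorter chain such as acetyl, a chain of intermediate length, or a chain ending in an amine or a carboxylic acid would do at this place. As far as these compounds go, compound 2 alone gives an actual number, 69000 nM, so whether the length of the ester chain matters at all in this assay also remains open.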